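Tert-butyl to hydrogen on the benzoyl ring

A few compounds are considered here, and "the series" means these few. Any claim that something is new, unique, unknown or untested is made for them only; others in the source may bear on it.

Compound 1 `Nc1ncnc2c1c(-c1ccc(Oc3ccccc3)cc1)cn2[C@H]1CCN(C[C@H]2CO2)C1` stands at the limit of > 50000 nM in a functional assay on Ramos cells (Homo sapiens) for antiproliferative activity (on this read-out higher numbers stand for weaker inhibition and lower numbers for stronger inhibition), which is a limit and not a number. For the measured compounds named here, compound 2 `CC(C)(C)c1ccc(C(=O)Nc2ccc(-c3cn([C@H]4CCN(C[C@@H]5CO5)C4)c4ncnc(N)c34)cc2)cc1` gives 2970 nM in this assay, the only number so far. The single other entry is a limit, as compound 1 shows (the limit of > 50000 nM in this assay, at which 1 of the 2 values shown sits). Compound 3 `Nc1ncnc2c1c(-c1ccc(NC(=O)c3ccccc3)cc1)cn2[C@H]1CCN(C[C@@H]2CO2)C1` differs from compound 2 by hydrogen in place of tert-butyl on an aromatic carbon. Going by the values given here, no measured step of this kind exists, so its size is uncertain; the step of a 3.0-fold higher number from compound 2 to compound 3 (0.48 log units; beyond the scatter) is expected to weaken inhibition beyond the scatter. Compound 3 is estimated at 9000 nM, between 2500 nM and 30000 nM, in this assay.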

Compound 3, half-maximal inhibitory concentration: 2250 nM
For compound 3 the middle estimate is 4.0-fold (0.60 log units) above the measured one, and the stated range ends above it.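

In this assay, for the compounds shown here, replacing tert-butyl with hydrogen on the aromatic carbon gives a 1.3-fold lower number from compound 2 to compound 3 (0.12 log units; within the scatter), the first measured step at this position. In this pair, 4-(tert-butyl)phenyl and phenyl are therefore not told apart, so the tert-butyl group is not needed to hold the value on this read-out. Nothing at hand accounts for this result.

Going by these compounds, whether an amine, a carboxylic acid or a methoxy group at the same position would read alike remains open. On these data alone, compound 1 differs from compound 2 and compound 3 in more than one place, so what separates its limit from their values also remains open.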